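This account rests on a few compounds, and the source may have more. Where it says the series, first, only, none or still open, it means among the compounds named here.

Measured compounds:
Compound 1, `CCC(CC)C(N)CCN(C(=O)[C@@H]1C[C@H]1c1ccccc1)c1ccc(-c2ccccc2)cc1`: 2 nM
Compound 2, `CC(C)C[C@H](N)CN(C(=O)[C@@H]1C[C@H]1c1ccccc1)c1ccc(-c2cccnc2)cc1`: 10000 nM
Compound 3, `CC[C@H](C)[C@H](N)CN(C(=O)[C@@H]1C[C@H]1c1ccccc1)c1ccc(-c2ccc(OC(C)C)cc2)cc1`: 72 nM

In a functional assay for agonist activity at G protein-coupled receptor 88 (Homo sapiens), read by HTRF and cAMP accumulation (on this read-out higher numbers stand for an effect only at larger amounts of compound and lower numbers for an effect already at smaller amounts), compound 3 gives 72 nM, the second highest of the three numbers. Compound 1 gives 2 nM, a lower number that lies beyond the scatter of repeated measurements. Compound 2 gives 10000 nM, a higher number, again beyond the scatter. The three compounds thus span a wide range, and compound 3 sits between the other two on this assay.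

Compound 4, `CCOC(=O)c1ccc(-c2ccc(N(C[C@@H](N)[C@@H](C)CC)C(=O)[C@@H]3C[C@H]3c3ccccc3)cc2)cc1`, is not yet measured. It differs from compound 3 in one place: ethoxycarbonyl in place of isopropoxy on an aromatic carbon. Within the data shown here, no pair of measured compounds shows this same change, so there is no measured step to lean on. What the three measured compounds do show is that changes around the distal aromatic ring move the numbers on this assay over a wide range. Compound 4 keeps the rest of the structure of compound 3 unchanged. For compound 4 the expected value is 150 nM, with a range from 25 nM to 900 nM. This estimate means a step of a 2.1-fold higher number from compound 3 to compound 4 (0.32 log units; beyond the scatter), which is expected to be small, toward a higher number, and at most modestly beyond the scatter.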

Compound 4, half-maximal effective concentration: 260 nM
For compound 4 the middle estimate is 1.7-fold (0.24 log units) below the measured one; the measured number falls inside the stated range.
By their numbers in this assay, from the lowest: compound 1; then compound 3; then compound 4; then compound 2.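

In this assay, among these compounds, the exchange of 4-isopropoxyphenyl for 4-(ethoxycarbonyl)phenyl provides the first step in this set in which only one place differs, a 3.6-fold higher number from compound 3 to compound 4 (0.56 log units; beyond the scatter), and so gives the first direct reading of this position. On this aromatic carbon, para to a large group, a substituent joined through a carbonyl and carrying one more hydrogen-bond acceptor than isopropoxy therefore moves the number only modestly, though beyond the scatter, toward needing more compound, so the position accepts both groups without a large change on this read-out. The information available gives no measured account of why the number moves in this direction.

How a carboxylic acid, a primary amide, a nitrile or a longer alkoxy chain at this position would read remains open, so the compounds shown do not separate the contribution of the carbonyl from that of the ethyl part of the ester. Also open, from the compounds shown here alone, is whether the same exchange would give a step of similar size and direction on the amine side chain of compound 1.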